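From cyclohexyl to 2-chlorophenyl, starting at a limit

This account rests on a few compounds, and the source may have more. Where it says the series, first, only, none or still open, it means among the compounds named here.

In a functional assay on HepG2 cells (Homo sapiens) for antiproliferative activity, read by MTT assay, with a stated time of 48 h (on this read-out higher numbers stand for weaker inhibition and lower numbers for stronger inhibition), compound 1 `O=C(Nc1cccc(CNc2nccnc2Cl)c1)NC1CCCC1` gives 18400 nM. Compound 2 `O=C(Nc1cccc(CNc2nccnc2Cl)c1)NC1CCCCC1` gives > 40000 nM, which is a limit of the assay and not a number. Compound 3 `O=C(Nc1cccc(CNc2nccnc2Cl)c1)Nc1ccccc1Cl` differs from it by 2-chlorophenyl in place of cyclohexyl on an amide-type nitrogen. For the measured compounds named here, one measured step bears on this nitrogen: an at least 2.1-fold higher number from compound 1 to compound 2 (0.33 log units; beyond the scatter). That step shows that the group here can shift the number in this assay, so a modest move towards stronger inhibition is expected. The expected change is an at least 2.0-fold lower number from compound 2 to compound 3 (0.30 log units; that floor lies within the scatter). Compound 3 is estimated at 20000 nM, with an expected range of 6000 nM to 40000 nM.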

Compound 3, half-maximal inhibitory concentration: 8560 nM
The estimate for compound 3 lay 2.3-fold (0.37 log units) above the measured number; the range from low to high includes it.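

The earlier pair showed only a rise in the number on this amide-type nitrogen. In this assay 2-chlorophenyl now gives an at least 4.6-fold lower number from compound 2 to compound 3 (0.66 log units; beyond the scatter) and also a 2.1-fold lower number from compound 1 to compound 3 (0.33 log units; beyond the scatter), so this position can move the number down as well, here with an aromatic ring in place of a non-aromatic one. The first of these steps has no exact size, since compound 2 stands at a limit of the assay and not at a number: the limit of > 40000 nM in this assay, at which 1 of the 3 values shown sits. As far as these compounds go, what the chlorine adds to the aromatic ring stays open, and so does how a plain phenyl or a benzyl group would compare.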